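Replacing a pyrazolyl amide with an acetylazetidinyl amide

The source may report more compounds than this note shows. Statements on the series, on what has been measured and on what is new or still open speak of the compounds shown alone.

Two compounds have numbers in an assay on lysate for inhibition of 6-phosphofructo-2-kinase/fructose-2,6-bisphosphatase 3 (Homo sapiens), with stated times of 0.5 min and 45 min (a lower number here means a stronger inhibitor, a higher number a weaker inhibitor), so far. Compound 1 `Cn1ccc2ccc(-c3cc(Nc4ccccc4S(=O)(=O)N4CCOCC4)cc4nccnc34)cc21` gives 2640 nM in this assay. Compound 2 `Cn1cc(NC(=O)c2ccncc2Nc2cc(-c3ccc4ccn(C)c4c3)c3nccnc3c2)cn1` gives 26500 nM in this assay, the higher of the two numbers; its gap to compound 1 lies beyond the scatter, so compound 2 is the weaker of the pair. Going by the values given here, no single-point step between measured compounds has been recorded.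

Compound 3 `CC(=O)N1CC(NC(=O)c2ccncc2Nc2cc(-c3ccc4ccn(C)c4c3)c3nccnc3c2)C1` differs from compound 2 at one place only: 1-acetylazetidin-3-yl in place of 1-methyl-1H-pyrazol-4-yl on an amide-type nitrogen. Nothing among the two measured compounds speaks to this particular exchange, so the direction of the step cannot be read from them. Compound 3 is therefore expected to stay close to compound 2, with a step from compound 2 to compound 3 of a 1.3-fold lower number from compound 2 to compound 3 (0.12 log units; within the scatter) that need not exceed the scatter. The estimate for compound 3 in this assay is 20000 nM, within a range from 7000 nM to 60000 nM.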

Compound 3, half-maximal inhibitory concentration: 97400 nM
Beside the measured number, compound 3's estimate is 4.9-fold (0.69 log units) below it, outside the stated range (above it).
By their numbers in this assay, from the lowest: compound 1; then compound 2; then compound 3.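

In this assay, the group on the amide-type nitrogen proves to matter: 1-acetylazetidin-3-yl in place of 1-methyl-1H-pyrazol-4-yl gives a 3.7-fold higher number from compound 2 to compound 3 (0.57 log units; beyond the scatter), so this first single-point step in the series makes the inhibitor weaker. The exchange replaces a five-membered aromatic ring with a four-membered non-aromatic ring and brings in an acetyl group, all in one step, so the result applies to the change as a whole and not to any one of its parts. No measurement is available that accounts for the size or direction of this step.

The compounds shown do not separate the ring from the acetyl group, and they leave open how a free azetidin-3-yl or a phenyl ring would read on the same nitrogen. From the compounds shown here alone, whether any group at this place can give a lower number than compound 2 also remains open.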